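Fluoro in Place of Chloro on the Benzyl Group

The source may hold more compounds than are shown below. What is called first, only, known or untested is meant among the compounds shown, and "the series" means these compounds.

Measured so far in a functional assay on MGC-803 cells (Homo sapiens) for inhibition, read by MTT assay, with a stated time of 72 h; a higher number here means a weaker inhibitor, a lower number a stronger inhibitor:
- compound 1 `C#CCSc1nc(Nc2ccc(Cl)cc2)c(C#N)c(-c2ccccc2)n1`: > 128000 nM, a limit of the assay
- compound 2 `Cc1ccccc1Nc1nc(SCc2cn(Cc3ccc(Cl)cc3)nn2)nc(-c2ccccc2)c1C#N`: > 64000 nM, a limit of the assay
- compound 3 `Cc1ccc(Nc2nc(SCc3cn(Cc4ccc(Cl)cc4)nn3)nc(-c3ccccc3)c2C#N)cc1`: 19600 nM

Compound 3 is the only one of the three with a definite number; its half-maximal inhibitory concentration in this assay stands at 19600 nM. For compound 1 the result is only a limit, (the limit of > 128000 nM in this assay, at which 1 of the 3 values shown sits). For compound 2 the result is likewise only a limit, (the limit of > 64000 nM in this assay, at which 1 of the 3 values shown sits). Going by the values given here, the single measured step, an at least 3.2-fold lower number from compound 2 to compound 3 (0.51 log units; beyond the scatter), concerns the methylphenyl on the nitrogen and not the benzyl group.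

Compound 4 `Cc1ccc(Nc2nc(SCc3cn(Cc4ccc(F)cc4)nn3)nc(-c3ccccc3)c2C#N)cc1` differs from compound 3 by one change: fluoro in place of chloro on an aromatic carbon. No measured step touches this part of the molecule, so the data shown give no direction for it. The step is expected to stay within the scatter, a 1.0-fold higher number from compound 3 to compound 4 (0.01 log units; within the scatter). Compound 4 is therefore estimated at 20000 nM in this assay, with a range from 8000 nM to 50000 nM.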

Compound 4, half-maximal inhibitory concentration: > 64000 nM
Compound 4 ended at the assay's limit; the forecaster's own chance of this, stated with the estimate: 15%; middle value at least 3.2-fold (0.50 log units) from the limit.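

Going by these compounds alone, the halogen on this benzyl group matters more than the earlier compounds could show: fluoro in place of chloro gives an at least 3.2-fold higher number from compound 3 to compound 4 (0.51 log units; beyond the scatter) in this assay, the first measured step at this position. Of the two compounds with the 4-methylphenyl on the nitrogen, only compound 3, which carries the 4-chlorobenzyl group, gives a definite number. The result for compound 4 is a limit and not a number, so the full size of the step stays unknown: the limit of > 64000 nM in this assay, at which 2 of the 4 values shown sit.

From the compounds shown here alone, whether chloro itself is needed, or whether bromo, methyl or methoxy at this place would serve as well, remains open. So does whether a benzyl group with no substituent at all would read like compound 3 or like compound 4.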